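Benzyl in Place of Cyclopropyl on the Sulfonamide Nitrogen

A few compounds are considered here, and "the series" means these few. Any claim that something is new, unique, unknown or untested is made for them only; others in the source may bear on it.

Three compounds share one core and differ only in the group on a sulfonamide nitrogen in a ring. Compound 1 `CC(C)CC1n2cncc2CN(CC2CC2)S1(=O)=O` carries a cyclopropylmethyl group, and in an assay on cells for inhibition of cytochrome P450 11B2, mitochondrial (Homo sapiens) (on this read-out higher numbers stand for weaker inhibition and lower numbers for stronger inhibition), compound 1 gives 758 nM. Compound 2 `CC(C)CC1n2cncc2CN(Cc2ccc(OC(F)(F)F)cc2)S1(=O)=O` carries a trifluoromethoxy-substituted benzyl group, and in this assay compound 2 gives 104 nM. Compound 3 `CC(C)CC1n2cncc2CN(C2CC2)S1(=O)=O` carries a plain cyclopropyl group. In this assay compound 3 reaches only > 1000 nM, which is a limit of the measurement and not a number. So compound 3 sits at the limit of > 1000 nM in this assay, at which 1 of the 3 values shown sits. Within the data shown here, the only measured step that touches this position is an at least 1.3-fold higher number from compound 1 to compound 3 (0.12 log units; that floor lies within the scatter), whose true size is open since it rests on a limit. The change considered now is benzyl in place of cyclopropyl on a sulfonamide nitrogen in a ring, which gives compound 4 `CC(C)CC1n2cncc2CN(Cc2ccccc2)S1(=O)=O`. Compound 2 shows that a benzyl-type group yields a measured number well inside the assay range. Compound 4 is therefore expected to land near 200 nM, within a range from 60 nM to 700 nM. That would correspond to an estimated step of an at least 5.0-fold lower number from compound 3 to compound 4 (0.69 log units; beyond the scatter).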

Compound 4, half-maximal inhibitory concentration: 18.6 nM
The estimate for compound 4 lay 11-fold (1.03 log units) above the measured number; measured number outside the range, below it.
By their numbers in this assay, from the lowest: compound 4; then compound 2; then compound 1. At a limit, above all of these: compound 3.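

In this assay, the benzyl group on the sulfonamide nitrogen gives a far lower number than plain cyclopropyl, with an at least 53-fold lower number from compound 3 to compound 4 (1.73 log units; beyond the scatter) as the step, and that size is only a floor, as the entry for compound 3 is a limit: the limit of > 1000 nM in this assay, at which 1 of the 4 values shown sits. Phenyl in place of cyclopropyl on the saturated chain carbon also matters greatly, with a 41-fold lower number from compound 1 to compound 4 (1.61 log units; beyond the scatter) as the step. Hydrogen in place of trifluoromethoxy on the aromatic carbon gives a 5.6-fold lower number from compound 2 to compound 4 (0.75 log units; beyond the scatter) as a further step, so the unsubstituted benzyl group of compound 4 gives the lowest number of the four.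

The compounds shown leave open whether a small group on that aromatic ring, such as fluorine or methoxy, would keep this low number. They also leave open how a longer chain in place of the isobutyl group would change it.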